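The compounds below may be only part of what the source reports. "The series", "measured", "known", "first", "only" and "open" are said of these compounds alone.

Measured so far in a functional assay on MGC-803 cells (Homo sapiens) for antiproliferative activity, read by CCK-8 assay, with a stated time of 72 h, tested at 8 uM; on this read-out higher numbers stand for a stronger effect at the one concentration tested and lower numbers for a weaker effect:
- compound 1, `Nc1ccccc1NC(=O)c1ccc(CSC(=S)N2CCN(C(c3ccccc3)c3ccccc3)CC2)cc1`: 9.9%
- compound 2, `Nc1ccccc1NC(=O)c1ccc(CSC(=S)N2CCCc3ccccc32)cc1`: 87.5%
- compound 3, `Nc1ccccc1NC(=O)c1ccc(CSC(=S)N2CCN(c3ccc(F)cc3)CC2)cc1`: 48.7%

Compound 3 stands second highest of the three numbers in this assay. Its nearest neighbour is compound 2, whose value lies higher by a margin beyond the usual scatter; its furthest is compound 1, whose value lies lower by the same margin, also beyond the scatter. All three share the same core and differ only in the group that is joined to the dithiocarbamate nitrogen.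

Compound 4, `CN1CCN(C(=S)SCc2ccc(C(=O)Nc3ccccc3N)cc2)CC1`, has not yet been measured. It differs from compound 3 in one place: methyl in place of 4-fluorophenyl on an amine nitrogen in a ring. Going by the values given here, no pair of measured compounds shows a step of exactly this kind, so the size of the step has to be guessed from the spread of the three numbers alone. Compound 1 carries a larger group on the same ring nitrogen and gives the lowest number; compound 3 carries a smaller one and gives a middle number; compound 2 lacks the second ring nitrogen altogether and gives the highest. On this evidence no step beyond the scatter is expected in this assay from compound 3 to compound 4 in either direction.

Compound 4 is therefore estimated at 50% in this assay, with a range from 20% to 80%. That estimate means an expected step of a number 1.3 percentage points higher from compound 3 to compound 4 (within the scatter).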

Compound 4, a percentage reported as inhibition, at one concentration (the size of the read-out at that concentration, not a potency): 84.4%
Beside the measured number, compound 4's estimate is 34.4 percentage points below it; measured number outside the range, above it.
By their numbers in this assay, from the lowest: compound 1; then compound 3; then compounds 4 and 2 (each within the scatter of the next).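

In this assay, the group on the amine nitrogen in the six-membered non-aromatic ring has a large bearing on the read-out: methyl in place of 4-fluorophenyl gives a number 35.7 percentage points higher from compound 3 to compound 4 (beyond the scatter). The second ring nitrogen is therefore compatible with a high number once it carries methyl, and the middle value of the earlier fluorinated compound does not describe this ring as a whole: 4-methylpiperazin-1-yl in place of 1,2,3,4-tetrahydroquinolin-1-yl on a thiocarbonyl carbon gives a number 3.1 percentage points lower from compound 2 to compound 4 (within the scatter), so these two groups cannot be told apart in this read-out. No measurement on hand accounts for either step.

As far as these compounds go, it remains open whether the high number holds with a hydrogen, an ethyl group or a longer chain on this nitrogen, and how far the number falls with a group of intermediate size, such as benzyl. A read-out at one concentration on one cell line also leaves the potency of compound 4 and compound 2 unresolved, and a full concentration series would be needed to separate them.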